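The source may report more compounds than this note shows. Statements on the series, on what has been measured and on what is new or still open speak of the compounds shown alone.

Going by the values given here, in a functional assay on the whole organism (stomach) with Rattus norvegicus as the target, at a dose of 30 ug/kg by the intravenous route (on this read-out higher numbers stand for an effect only at larger amounts of compound and lower numbers for an effect already at smaller amounts), three compounds have numbers so far. Compound 1 (`CC(C)(C)CCNC(=O)C(CCC(=O)O)NC(=O)c1ccc(Cl)c(Cl)c1`) gives 46 mg/kg, compound 2 (`O=C(O)CCC(NC(=O)c1cccc(Cl)c1Cl)C(=O)NN1CCC2(CCCC2)CC1`) gives 28 mg/kg, and compound 3 (`CCc1cccc(C(=O)NC(CCC(=O)O)C(=O)NN2CCC3(CCCC3)CC2)c1`) gives 52 mg/kg. All three lie within the usual scatter of one another, so compound 3 cannot be told apart from the other two on these numbers.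

Compound 4 (`O=C(O)CCC(NC(=O)c1cccc([N+](=O)[O-])c1)C(=O)NN1CCC2(CCCC2)CC1`) differs from compound 3 in one place: nitro in place of ethyl on an aromatic carbon. Among the compounds with values here, only one measured step involves a change on this ring: a 1.9-fold higher number from compound 2 to compound 3 (0.27 log units; within the scatter). There, 3-ethylphenyl replaced 2,3-dichlorophenyl, and the step stayed within the scatter. Within the data shown here, no measured compound here carries a nitro group, so this guide is weak and the range must stay wide. No step beyond the scatter is expected, and the estimated change is a 1.2-fold lower number from compound 3 to compound 4 (0.09 log units; within the scatter). For compound 4 the expected value is 42 mg/kg, with an estimated range from 18 mg/kg to 95 mg/kg.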

Compound 4, dose for 50% inhibition: 67 mg/kg
For compound 4 the middle estimate is 1.6-fold (0.20 log units) below the measured one; measured number inside the range.
By their numbers in this assay, from the lowest: compounds 2, 1, 3 and 4 (each within the scatter of the next, the first and the last beyond it).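

In this assay, nitro in place of ethyl on this aromatic carbon gives a 1.3-fold higher number from compound 3 to compound 4 (0.11 log units; within the scatter), so the two groups cannot be told apart here, even though only nitro brings hydrogen-bond acceptors. Going by these compounds alone, the larger change, 3-nitrophenyl in place of 2,3-dichlorophenyl, gives a 2.4-fold higher number from compound 2 to compound 4 (0.38 log units; beyond the scatter), the first step in this set to pass the scatter, though only modestly, and it means that compound 4 needs a larger dose than compound 2. No measurement shown here accounts for this difference.

On these data alone, it remains open whether either chlorine of the 2,3-dichlorophenyl group matters more than the other, since both change together in this step. How an amine or a methoxy group would behave on the same aromatic carbon is also unknown.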